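Trimethoxyphenyl replaces methoxyphenyl on the triazole benzyl arm

The source may hold more compounds than are shown below. What is called first, only, known or untested is meant among the compounds shown, and "the series" means these compounds.

Of the compounds shown here, three sharing one core have been tested in a functional assay on MIA PaCa-2 cells (Homo sapiens) for antiproliferative activity, read by sulforhodamine B assay, with a stated time of 48 h; a lower number here means a stronger inhibitor of growth, a higher number a weaker inhibitor of growth. Compound 1 `COc1cc(Cn2cc(CNC(=O)c3cn(-c4ccccc4)nc3-c3ccccc3)nn2)cc(OC)c1OC` gives 1000 nM. Compound 2 `O=C(NCc1cn(Cc2ccc(F)cc2)nn1)c1cn(-c2ccccc2)nc1-c1ccc(F)cc1` gives 14300 nM. Compound 3 `COc1ccc(Cn2cc(CNC(=O)c3cn(-c4ccccc4)nc3-c3ccc(F)cc3)nn2)cc1` gives 3700 nM, the second highest of the three numbers, with compound 1 nearest and compound 2 furthest.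

Among the compounds with values here, the one measured step, a 3.9-fold lower number from compound 2 to compound 3 (0.59 log units; beyond the scatter), is modest and concerns the aromatic carbon substituent on the benzyl arm. Compound 4 `COc1cc(Cn2cc(CNC(=O)c3cn(-c4ccccc4)nc3-c3ccc(F)cc3)nn2)cc(OC)c1OC` is made from compound 3 by the change (3,4,5-trimethoxyphenyl in place of 4-methoxyphenyl on a saturated chain carbon bound to an aromatic nitrogen). Within the data shown here, no measured pair isolates exactly this change, but compound 1 already carries the entering 3,4,5-trimethoxyphenyl group together with an unsubstituted phenyl elsewhere, and compound 1 gives a lower number than compound 3, while the only measured step along the benzyl arm also lowered the number. This step is therefore expected to be roughly a 2.5-fold lower number from compound 3 to compound 4 (0.39 log units; beyond the scatter) in this assay. Compound 4 is estimated at 1500 nM, within a range from 500 nM to 4500 nM.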

Compound 4, concentration for 50% growth inhibition: 5200 nM
Compound 4: middle estimate off by 3.5-fold (0.54 log units), on the low side, and the stated range ends below it.
By their numbers in this assay, from the lowest: compound 1; then compounds 3 and 4 (each within the scatter of the next); then compound 2.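

In this assay, 3,4,5-trimethoxyphenyl in place of 4-methoxyphenyl gives a 1.4-fold higher number from compound 3 to compound 4 (0.15 log units; within the scatter), so at this position the assay does not separate the two groups. Replacing 4-fluorophenyl with the 3,4,5-trimethoxyphenyl group gives a 2.8-fold lower number from compound 2 to compound 4 (0.44 log units; beyond the scatter), while fluoro in place of hydrogen on an aromatic carbon gives a 5.2-fold higher number from compound 1 to compound 4 (0.72 log units; beyond the scatter), so the low number of compound 1 goes with the absence of that fluoro and not with the 3,4,5-trimethoxyphenyl group alone. No measurement available here explains any of these steps.

As far as these compounds go, it remains open whether 4-methoxyphenyl and 3,4,5-trimethoxyphenyl would also read alike on the core of compound 1, which lacks the fluoro. From the compounds shown here alone, how an amine or a carboxylic acid on the benzyl arm would read also remains open.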